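Acetoxy in place of methoxy at the chain end

The source may hold more compounds than are shown below. What is called first, only, known or untested is meant among the compounds shown, and "the series" means these compounds.

The measured compounds:
compound 1, `COCCCCCCCCCCCCCCC/C=C1\CC(CO)(COC(=O)C(C)(C)C)OC1=O`, 5.45 ug/mL
compound 2, `CC(C)(C)C(=O)OCC1(CO)C/C(=C/CCCCCCCCCCCCCCC=O)C(=O)O1`, > 10 ug/mL
compound 3, `CCCCCOCCCCCCC/C=C1\CC(CO)(COC(=O)C(C)(C)C)OC1=O`, 3 ug/mL

For the measured compounds named here, in a functional assay on Hs-578T cells (Homo sapiens) for antiproliferative activity (on this read-out lower numbers stand for stronger inhibition of growth and higher numbers for weaker inhibition of growth), compound 1 and compound 3 sit within the scatter of each other, the step of a 1.8-fold lower number from compound 1 to compound 3 (0.26 log units; within the scatter) being the only measured step. Compound 2 does not give a number in this assay, only the limit (the limit of > 10 ug/mL in this assay, at which 1 of the 3 values shown sits). Compound 1 is thus one of two compounds with a number, and its nearest neighbour is compound 3.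

Compound 4, `CC(=O)OCCCCCCCCCCCCCCC/C=C1\CC(CO)(COC(=O)C(C)(C)C)OC1=O`, differs from compound 1 by acetyl in place of methyl on an oxygen on a saturated carbon. Going by the values given here, no measured step changes the end of the long chain in the same way: the one measured step alters the chain between the ether oxygen and the ring, and it stays within the scatter. Among the compounds with values here, the aldehyde-ended compound 2 gives only a limit, so the end of the chain can matter, but no step quantifies it. On this basis the acetyl is expected to leave the number near that of compound 1, with wide uncertainty, the expected step being a 1.1-fold higher number from compound 1 to compound 4 (0.04 log units; within the scatter). Compound 4 is therefore estimated at 6 ug/mL, within a range from 3 ug/mL to 12 ug/mL.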

Compound 4, concentration for 50% growth inhibition: > 10 ug/mL
Compound 4 was reported as a limit (the forecaster's own chance of this, stated with the estimate: 20%); middle value at least 1.6-fold (0.22 log units) away from the limit.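

The change from methyl to acetyl on this oxygen gives an at least 1.8-fold higher number from compound 1 to compound 4 (0.26 log units; that floor lies within the scatter) in this assay, and this floor comes from a limit rather than a number, so the true gap may be larger, although the floor alone does not establish a real loss of growth inhibition. The comparison with the shorter ether gives an at least 3.3-fold higher number from compound 3 to compound 4 (0.52 log units; beyond the scatter) and this one does lie beyond the scatter, which separates compound 4 from compound 3 even though compound 1 and compound 3 cannot be told apart. Compound 4 now joins compound 2 at the limit, while compound 1 and compound 3, both ethers, keep real numbers, so among these compounds what sits on the chain can decide whether a number is obtained at all: the limit of > 10 ug/mL in this assay, at which 2 of the 4 values shown sit.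

Going by these compounds, how far beyond the limit compound 2 and compound 4 lie remains unknown, so these two cannot be ranked against each other. Nothing shown tells how a free hydroxyl, an amine or a carboxylic acid at the end of the long chain would read, or whether a shorter acetoxy-ended chain would return a measurable number.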